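Benzyl substituent changes on the shared core

This account rests on a few compounds, and the source may have more. Where it says the series, first, only, none or still open, it means among the compounds named here.

Measured so far in a functional assay on SK-MEL-28 cells (Homo sapiens) for inhibition, read by MTT assay, with a stated time of 48 h; on this read-out higher numbers stand for weaker inhibition and lower numbers for stronger inhibition:
compound 1, `COc1ccc(C/N=C2\NC(=O)/C(=C3\CCNC(=O)c4[nH]ccc43)S2)cc1`: 12100 nM
compound 2, `O=C1N/C(=N\Cc2ccc(C(F)(F)F)cc2)S/C1=C1/CCNC(=O)c2[nH]ccc21`: a limit, > 100000 nM
compound 3, `O=C1N/C(=N\Cc2ccc(Cl)cc2)S/C1=C1/CCNC(=O)c2[nH]ccc21`: a limit, > 100000 nM

For the measured compounds named here, compound 1, with methoxy on the benzyl ring, is the only member with a numerical value. Compound 3 stands at a limit of this assay and gives no number. The same holds for compound 2, so two of the three values sit at the limit of > 100000 nM in this assay, at which 2 of the 3 values shown sit. Going by the values given here, the steps of an at least 8.2-fold higher number from compound 1 to compound 3 (0.91 log units; beyond the scatter) and an at least 8.2-fold higher number from compound 1 to compound 2 (0.91 log units; beyond the scatter) both run from the one readable value to the limit and are beyond the scatter. The step that the two limits leave unreadable from compound 2 to compound 3 cannot be read, as both ends are limits.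

Compound 4, `Cc1ccc(C/N=C2\NC(=O)/C(=C3\CCNC(=O)c4[nH]ccc43)S2)cc1`, is not yet measured. It differs from compound 3 by methyl in place of chloro on an aromatic carbon. The two measured steps that bear on this position both point the same way: moving away from methoxy raised the number out of range. Among the compounds with values here, no measured step shows what a methyl does here, so the expectation is uncertain. A weak value is expected for compound 4, with the step of an at least 1.6-fold lower number from compound 3 to compound 4 (0.22 log units; that floor lies within the scatter) estimated to stay within the region where only a limit may be reported. The estimate for compound 4 in this assay is 60000 nM, within 12000 nM to 150000 nM.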

Compound 4, half-maximal inhibitory concentration: 4150 nM
Compound 4: the middle estimate sits 14-fold (1.16 log units) above what was measured; the whole stated range lies above it.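

In this assay, the position para to a large group on the benzyl ring can carry a group other than methoxy and still give a numerical value: the step is a 2.9-fold lower number from compound 1 to compound 4 (0.46 log units; beyond the scatter), which makes compound 4 the strongest of the four shown and shows that leaving methoxy does not by itself push the value out of range. The exchange of chloro for methyl, with no change in heavy-atom count and no hydrogen-bond donor or acceptor on either side, is far from neutral, at an at least 24-fold lower number from compound 3 to compound 4 (1.38 log units; beyond the scatter), and the exchange of trifluoromethyl for methyl gives an at least 24-fold lower number from compound 2 to compound 4 (1.38 log units; beyond the scatter). Compound 2 and compound 3 remain limits rather than numbers, so these two large steps are floors and their full size cannot be read: the limit of > 100000 nM in this assay, at which 2 of the 4 values shown sit.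

The four compounds do not settle why methyl and methoxy give numbers while chloro and trifluoromethyl give only limits, and no property of these groups is given here to explain it. Also open, from the compounds shown here alone, is how an amine, a carboxylic acid or a longer chain such as ethyl would read at this position in this assay.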